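The source may report more compounds than this note shows. Statements on the series, on what has been measured and on what is new or still open speak of the compounds shown alone.

In a functional assay on HT-29 cells (Homo sapiens) for cytotoxicity, read by sulforhodamine B assay (on this read-out lower numbers stand for stronger inhibition and higher numbers for weaker inhibition), the series reads as follows.

- Compound 1 `C=C1[C@@H](OC(C)=O)C[C@@H]2[C@](C)(CO[Si](C)(C)C(C)(C)C)[C@H](OC(C)=O)CC[C@@]2(C)[C@@H]1C[C@@H](Nc1ccc(F)cc1)C1=CCOC1=O` gives 4940 nM
- Compound 2 `C=C1[C@@H](OC(C)=O)C[C@@H]2[C@](C)(COC=O)[C@H](OC(C)=O)CC[C@@]2(C)[C@@H]1C[C@@H](Nc1ccccc1C(=O)O)C1=CCOC1=O` gives 28700 nM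
- Compound 3 `C=C1[C@@H](OC(C)=O)C[C@@H]2[C@](C)(CO[Si](C)(C)C(C)(C)C)[C@H](OC(C)=O)CC[C@@]2(C)[C@@H]1C[C@@H](Nc1ccccc1C(=O)O)C1=CCOC1=O` gives 5340 nM

Compound 2 has the highest of the three numbers. Compound 4 `C=C1[C@@H](OC(C)=O)C[C@@H]2[C@](C)(COC=O)[C@H](OC(C)=O)CC[C@@]2(C)[C@@H]1C[C@@H](Nc1ccc(F)cc1)C1=CCOC1=O` differs from it by 4-fluorophenyl in place of 2-carboxyphenyl on an amine nitrogen. The same swap, in the opposite direction, was measured as a 1.1-fold higher number from compound 1 to compound 3 (0.03 log units; within the scatter) and lies within the scatter. The other step, a 5.4-fold lower number from compound 2 to compound 3 (0.73 log units; beyond the scatter), changes the group on oxygen, which compound 4 shares with compound 2, so it is not crossed here. The swap has not been measured with that smaller group. No change beyond the scatter is therefore expected in this assay, and the expected size is a 1.1-fold lower number from compound 2 to compound 4 (0.04 log units; within the scatter). Compound 4 is estimated at 26000 nM, with an expected range from 11000 nM to 60000 nM.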

Compound 4, half-maximal inhibitory concentration: 20500 nM
Compound 4: the middle estimate sits 1.3-fold (0.10 log units) above what was measured; low and high end bracket the measured number.
By their numbers in this assay, from the lowest: compounds 1 and 3 (each within the scatter of the next); then compounds 4 and 2 (each within the scatter of the next).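

In this assay, the aryl swap on the amine nitrogen now also reads with the smaller group on oxygen, and again it stays within the scatter (a 1.4-fold lower number from compound 2 to compound 4 (0.15 log units; within the scatter)). The two cores therefore agree on this swap: the same change on two cores in this assay, a 1.1-fold higher number (0.03 log units; within the scatter) from compound 1 to compound 3 and a 1.4-fold higher number (0.15 log units; within the scatter) from compound 4 to compound 2, 1.3-fold (0.11 log units) apart, within the scatter of two such steps. With 4-fluorophenyl in place, the change on oxygen also recurs (a 4.1-fold higher number from compound 1 to compound 4 (0.62 log units; beyond the scatter)), matching its size on the 2-carboxyphenyl pair: the same change on two cores in this assay, a 5.4-fold lower number (0.73 log units; beyond the scatter) from compound 2 to compound 3 and a 4.1-fold lower number (0.62 log units; beyond the scatter) from compound 4 to compound 1, 1.3-fold (0.11 log units) apart, within the scatter of two such steps.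

Going by these compounds, what in the change on oxygen carries this step stays open. A free hydroxyl or an acetyl on that oxygen, or a plain phenyl or a pyridyl on the amine nitrogen, would test how far both readings hold.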